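The source may report more compounds than this note shows. Statements on the series, on what has been measured and on what is new or still open speak of the compounds shown alone.

Series of sulfonamides on a shared core. Compound 1 `COc1ccc(OC)c(S(=O)(=O)NC2=NCCN2C(=S)SN2CCn3c2nsc3=S)c1` carries a 2,5-dimethoxyphenyl on the sulfonyl sulfur. In a functional assay on KYSE-510 cells (Homo sapiens) for antiproliferative activity, read by crystal violet staining, with a stated time of 96 h (a higher number here means a weaker inhibitor of growth, a lower number a stronger inhibitor of growth), compound 1 gives only the limit >= 20000 nM. Compound 2 `O=S(=O)(NC1=NCCN1C(=S)SN1CCn2c1nsc2=S)c1ccc(Cl)c(Cl)c1` replaces that group with 3,4-dichlorophenyl. In this assay compound 2 likewise gives only the limit >= 20000 nM. Among the compounds with values here, the step that the two limits leave unreadable from compound 1 to compound 2 therefore cannot be read, and compound 2 stands at the limit of the assay with no number of its own, the same being true of the one further value shown (the limit of >= 20000 nM in this assay, at which 2 of the 2 values shown sit).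

Compound 3 `O=S(=O)(NC1=NCCN1C(=S)SN1CCn2c1nsc2=S)c1ccc(Cl)cc1Cl` is the next member. The change 2,4-dichlorophenyl in place of 3,4-dichlorophenyl on a sulfonyl sulfur moves one chlorine within the aryl group on the sulfonyl sulfur, the atoms staying the same. Within the data shown here, no measured step bears on it, and both measured values sit at the same limit, so no direction beyond the scatter can be expected. The estimate for compound 3 is 20000 nM (range 8000 nM to 40000 nM), a step of a number no higher from compound 2 to compound 3 (the limit leaves the size open) expected, most likely again reported only as a limit.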

Compound 3, concentration for 50% growth inhibition: >= 20000 nM
Compound 3 was reported as a limit; the forecaster's own chance of this, stated with the estimate: 80%; the middle value sits exactly at the limit.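

No step can be read among compound 1, compound 2 and compound 3, each reported only as a limit: the limit of >= 20000 nM in this assay, at which 3 of the 3 values shown sit.

Whether any change of the aryl group on the sulfonyl sulfur shifts growth inhibition in this assay at all, and by how much, stays open among the compounds shown.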